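A few compounds are considered here, and "the series" means these few. Any claim that something is new, unique, unknown or untested is made for them only; others in the source may bear on it.

Measured so far:
compound 1, `CCCCCC(=O)NCC(C)(C)CC1=C(O)C(=O)c2ccccc2C1=O`, 46600 nM in an ADME assay on Vero cells (Chlorocebus sabaeus) for cytotoxicity, read by reporter gene assay, with a stated time of 4 days; a higher number here means a weaker inhibitor, a lower number a stronger inhibitor
compound 2, `CCCCCCCCC(=O)NCC(C)(C)CC1=C(O)C(=O)c2ccccc2C1=O`, 16700 nM in this assay

Compound 2 holds the lowest of the two numbers in this assay; its nearest neighbour is compound 1, separated by the step of a 2.8-fold lower number from compound 1 to compound 2 (0.45 log units; beyond the scatter), a modest change that lies beyond the scatter.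

The next compound is compound 3, `CCCCCCCCCCCCCCCC(=O)NCC(C)(C)CC1=C(O)C(=O)c2ccccc2C1=O`. It differs from compound 2 in one place: heptyl in place of hydrogen on a saturated chain carbon, eight bonds along the chain from a carbonyl carbon.

Among the compounds with values here, only one measured step bears on this change, the one from compound 1 to compound 2, which added propyl on the same chain and gave a modest lowering. Compound 3 extends the chain by heptyl, a longer addition of the same kind. The expectation is therefore a further lowering, a 3.3-fold lower number from compound 2 to compound 3 (0.52 log units; beyond the scatter), of at least the size already seen and possibly more. Compound 3 is estimated at 5000 nM, with a range from 1500 nM to 16000 nM.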

Compound 3, half-maximal inhibitory concentration: 5600 nM
For compound 3 the middle estimate is 1.1-fold (0.05 log units) below the measured one; low and high end bracket the measured number.
By their numbers in this assay, from the lowest: compound 3; then compound 2; then compound 1.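

In this assay the lowering seen with the first chain extension does not stop at compound 2: the larger addition of heptyl, eight bonds along the chain from a carbonyl carbon, gives a 3.0-fold lower number from compound 2 to compound 3 (0.47 log units; beyond the scatter) and so carries the trend further. Taken as a single change, decyl in place of hydrogen, five bonds along the chain from a carbonyl carbon, gives an 8.3-fold lower number from compound 1 to compound 3 (0.92 log units; beyond the scatter) and places the three compounds in one order, with the number lower at each longer chain and none of them going against it. Nothing measured here gives a reason for this order.

As far as these compounds go, whether a still longer chain would lower the number further or end the trend remains open. So does the effect of an amine or a carboxylic acid at the far end of the chain.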